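The source may hold more compounds than are shown below. What is called first, only, known or untested is meant among the compounds shown, and "the series" means these compounds.

Measured so far in a functional assay on PC-3 cells (Homo sapiens) for cytotoxicity, read by sulforhodamine B assay, with a stated time of 48 h; on this read-out lower numbers stand for stronger inhibition and higher numbers for weaker inhibition:
- compound 1 `COc1ccc(/C=C/C(=O)/C=C/C2=C(C)CCCC2(C)C)cc1`: 58700 nM
- compound 2 `CC1=C(/C=C/C(=O)/C=C/c2ccc([N+](=O)[O-])cc2)C(C)(C)CCC1`: 1900 nM
- compound 3 `COc1ccccc1/C=C/C(=O)/C=C/C1=C(C)CCCC1(C)C`: 14200 nM

Compound 1 and compound 3 share the same atoms joined differently; the difference between the two cores is not broken down here. On this read-out compound 3 sits between the other two, its number lower than that of compound 1 and higher than that of compound 2.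

One change is seen once with a measurement: nitro in place of methoxy on an aromatic carbon. It gave a 31-fold lower number from compound 1 to compound 2 (1.49 log units; beyond the scatter).

Compound 4 `CC1=C(/C=C/C(=O)/C=C/c2ccccc2[N+](=O)[O-])C(C)(C)CCC1` is not yet measured. It arises from compound 3 by nitro in place of methoxy on an aromatic carbon. This is the same kind of change as that from compound 1 to compound 2, not the same: there the place was para to a large group, here it is ortho to a large group.

In this assay the step from compound 3 to compound 4 is expected to be an 18-fold lower number from compound 3 to compound 4 (1.25 log units; beyond the scatter), resting on the step of the same kind a 31-fold lower number from compound 1 to compound 2 (1.49 log units; beyond the scatter), with a wider band because the place differs. Compound 4 is thus estimated at 800 nM, expected between 200 nM and 4000 nM.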

Compound 4, half-maximal inhibitory concentration: 9500 nM
Compound 4: middle estimate off by 12-fold (1.07 log units), on the low side; the whole stated range lies below it.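

In this assay nitro in place of methoxy on an aromatic carbon, here ortho to a large group, gives a 1.5-fold lower number from compound 3 to compound 4 (0.17 log units; within the scatter) and does not repeat the large step seen on the other core. The same change therefore cannot be carried from one core to the other in this series at a fixed size: the same change on two cores in this assay, a 31-fold lower number (1.49 log units; beyond the scatter) from compound 1 to compound 2 and a 1.5-fold lower number (0.17 log units; within the scatter) from compound 3 to compound 4, 21-fold (1.32 log units) apart, beyond the scatter of two such steps. Among the compounds shown here, this shows that the size of the step depends on the pair in which it is made, but it does not show what sets that size, since the two pairs give only one step for each place of the group and the data cannot separate place from any other difference between the cores.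

Left open is how an amine, a carboxylic acid or a chlorine at the same places would compare with nitro and methoxy. Also open, from the compounds shown here alone, is whether a further pair of this kind, with nitrile in place of methoxy for instance, would show the same gap between the two cores.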